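Fluoro on the N-aryl ring: compound 3 to compound 4

The compounds below may be only part of what the source reports. "The series", "measured", "known", "first", "only" and "open" are said of these compounds alone.

Measured so far:
compound 1 `O=C(Nc1ccc(Oc2ccnc3[nH]ccc23)cc1)c1cn(-c2ccc(Cl)cc2)c2ccccc2c1=O` 650 nM
compound 2 `O=C(Nc1ccc(Oc2ccnc3[nH]ccc23)cc1)c1cn(-c2ccc(C(F)(F)F)cc2Cl)c2ccccc2c1=O` 2350 nM
compound 3 `Cn1ccc2c(Oc3ccc(NC(=O)c4cn(-c5ccccc5)c5ccccc5c4=O)cc3F)ccnc21` 1720 nM

In a functional assay on A549 cells (Homo sapiens) for inhibition, read by MTT assay, with a stated time of 72 h (a higher number here means a weaker inhibitor, a lower number a stronger inhibitor), compound 3 gives 1720 nM, the second highest of the three numbers. Compound 2 gives 2350 nM, which lies within the scatter of compound 3; compound 1 gives 650 nM, a lower number, beyond the scatter.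

Compound 4 `Cn1ccc2c(Oc3ccc(NC(=O)c4cn(-c5ccc(F)cc5)c5ccccc5c4=O)cc3F)ccnc21` differs from compound 3 by fluoro in place of hydrogen on an aromatic carbon. Among the compounds with values here, the only measured step on the same aromatic nitrogen substituent is a 3.6-fold higher number from compound 1 to compound 2 (0.56 log units; beyond the scatter), a modest rise for a larger change, 2-chloro-4-(trifluoromethyl)phenyl in place of 4-chlorophenyl, on a different core variant. Within the data shown here, no measured pair shows hydrogen to fluoro alone on this ring. A single fluorine is a smaller change than that step, so in this assay the expectation is a step of a 1.1-fold lower number from compound 3 to compound 4 (0.06 log units; within the scatter), not beyond the scatter, in either direction.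

Compound 4 is therefore expected to give about 1500 nM, with a range of 600 nM to 4000 nM.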

Compound 4, half-maximal inhibitory concentration: 1460 nM
For compound 4 the middle estimate is 1.0-fold (0.01 log units) above the measured one, and the stated range covers the measured number.
By their numbers in this assay, from the lowest: compound 1; then compounds 4, 3 and 2 (each within the scatter of the next).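

In this assay, within the data shown here, the change from phenyl to 4-fluorophenyl on the N-aryl ring gives a 1.2-fold lower number from compound 3 to compound 4 (0.07 log units; within the scatter) as the first step in which this ring alters by one heavy atom alone. At this place, para to a large group, fluoro in place of hydrogen therefore separates compound 3 and compound 4 by no more than the scatter, whereas the larger replacement in a 3.6-fold higher number from compound 1 to compound 2 (0.56 log units; beyond the scatter) on the other core goes beyond it. Nothing available bears on the cause of this result.

As far as these compounds go, whether an amine, a methoxy group or a carboxylic acid at this place would read differently from fluoro remains open. From the compounds shown here alone, it is also open whether hydrogen to fluoro alone on this ring would give a similar step on the core of compound 1.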